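A few compounds are considered here, and "the series" means these few. Any claim that something is new, unique, unknown or untested is made for them only; others in the source may bear on it.

Compound 2 `CCn1c(C(=O)NCC#N)ccc1C(CC)(CC)c1ccc(OCCC(O)(CC)CC)c(C)c1` is one of three close relatives, all sharing a core and differing only in the group on the amide-type nitrogen. In an ADME assay on L02 cells (Homo sapiens) for antiproliferative activity, read by MTT assay, with a stated time of 48 h (a lower number here means a stronger inhibitor, a higher number a weaker inhibitor), compound 2 gives > 50000 nM, which is a limit of the assay rather than a number. Compound 1 `CCN(CC)CCNC(=O)c1ccc(C(CC)(CC)c2ccc(OCCC(O)(CC)CC)c(C)c2)n1CC` gives 2290 nM in this assay. Compound 3 `CCC(C)C(CO)NC(=O)c1ccc(C(CC)(CC)c2ccc(OCCC(O)(CC)CC)c(C)c2)n1CC` gives > 50000 nM, again a limit. The measured steps are an at least 21-fold higher number from compound 1 to compound 2 (1.33 log units; beyond the scatter) and an at least 21-fold higher number from compound 1 to compound 3 (1.33 log units; beyond the scatter), while a step that the two limits leave unreadable from compound 2 to compound 3 because of the limit of > 50000 nM in this assay, at which 2 of the 3 values shown sit. Compound 4 `CCn1c(C(=O)NC(C)CO)ccc1C(CC)(CC)c1ccc(OCCC(O)(CC)CC)c(C)c1` carries the change (1-(hydroxymethyl)ethyl in place of cyanomethyl on an amide-type nitrogen). The hydroxymethyl group in compound 3 gave a limit, so compound 4 is expected to stay weak, a step that the limit leaves unreadable from compound 2 to compound 4. The estimate for compound 4 is 60000 nM, between 20000 nM and 200000 nM.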

Compound 4, half-maximal inhibitory concentration: 4840 nM
Estimate against measurement, compound 4: 12-fold (1.09 log units) above; the measured number lies below the stated range.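

Putting 1-(hydroxymethyl)ethyl on the amide-type nitrogen gives an at least 10-fold lower number from compound 2 to compound 4 (1.01 log units; beyond the scatter), and swapping sec-butyl for methyl on that chain gives an at least 10-fold lower number from compound 3 to compound 4 (1.01 log units; beyond the scatter), so a number within the assay's range does not require the 2-(diethylamino)ethyl group. That group still holds a modest edge, with a 2.1-fold higher number from compound 1 to compound 4 (0.33 log units; beyond the scatter). Compound 2 and compound 3 each sit at a limit, so the first two steps give only minimum sizes: the limit of > 50000 nM in this assay, at which 2 of the 4 values shown sit.

Still open, on these data alone, is how an ethyl group would read in place of that methyl, and whether a primary amine or a carboxylic acid in place of the hydroxymethyl would keep the number within range.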